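Removing the Ethyl Group from a Bicyclic Amide Acid

This account rests on a few compounds, and the source may have more. Where it says the series, first, only, none or still open, it means among the compounds named here.

Compound 1 `CCc1ccccc1NC(=O)C1C(C(=O)O)[C@@H]2CC[C@H]1O2` and compound 2 `O=C(O)C1C(C(=O)NCCCc2ccccc2)[C@H]2CC[C@@H]1O2` share a bicyclic core that carries a carboxylic acid and an amide. In an ADME assay on A2780 cells (Homo sapiens) for cytotoxicity, read by MTT assay, with a stated time of 72 h (a higher number here means a weaker inhibitor of growth, a lower number a stronger inhibitor of growth), compound 1 gives 10000 nM, and compound 2 gives 10000 nM; the two values are level at the digits recorded, and the gap between them lies within the scatter. Compound 1 thus stands together with compound 2, with nothing to set the two apart. Compound 3 `O=C(O)C1C(C(=O)Nc2ccccc2)[C@H]2CC[C@@H]1O2` has not been measured; it differs from compound 1 in one place: hydrogen in place of ethyl on an aromatic carbon. Among the compounds with values here, no step between measured compounds is available to weigh this change, and both measured values sit at the same figure. The expected step of no change at the digits printed from compound 1 to compound 3 (within the scatter) is none beyond the scatter, in no particular direction. For compound 3 the estimated value in this assay is 10000 nM, within a range from 5000 nM to 20000 nM.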

Compound 3, concentration for 50% growth inhibition: 10000 nM
Estimate against measurement, compound 3: no gap at the digits printed; measured number inside the range.
By their numbers in this assay, from the lowest: compounds 1, 2 and 3 (each within the scatter of the next).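

Within the data shown here, putting hydrogen in place of ethyl on an aromatic carbon gives no change at the digits printed from compound 1 to compound 3 (within the scatter) in this assay and so provides the first direct reading of a single change, which compound 1 and compound 2 could not offer. At this place, ortho to a large group, the ethyl group can be taken away from compound 1 with no shift in the number that can be told from scatter. No measurement here speaks to an explanation for this result.

The compounds shown leave open whether an amine, a hydroxyl group or a longer chain on the same aromatic carbon would move the value away from that of compound 3. They also leave open whether an ester or a primary amide in place of the carboxylic acid would change the reading.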